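Removing the nitro group from a triazole-linked trimethoxyphenyl series

The source may hold more compounds than are shown below. What is called first, only, known or untested is meant among the compounds shown, and "the series" means these compounds.

Compound 1 `COc1cc(-n2ncnc2-c2cccc([N+](=O)[O-])c2)cc(OC)c1OC` carries a nitro group on one of its two aryl rings. In a functional assay on K562 cells (Homo sapiens) for antiproliferative activity, read by MTT assay, with a stated time of 72 h (a lower number here means a stronger inhibitor, a higher number a weaker inhibitor), compound 1 gives > 10000 nM, which is a limit of the assay rather than a number. Its closest measured relatives share the core but place the substituents differently. Compound 2 `COc1ccc(-n2ncnc2-c2cc(OC)c(OC)c(OC)c2)cc1` gives 3600 nM in this assay. Compound 3 `COc1cc(-c2ncnn2-c2ccc(Cl)c(Cl)c2)cc(OC)c1OC` gives > 10000 nM in this assay, again a limit. Among the measured compounds shown here, the single measured step, an at least 2.7-fold higher number from compound 2 to compound 3 (0.44 log units; beyond the scatter), shows a swap on the aromatic nitrogen weakening activity, and it is shaped by the limit of > 10000 nM in this assay, at which 2 of the 3 values shown sit. Compound 4 `COc1cc(-n2ncnc2-c2ccccc2)cc(OC)c1OC` differs from compound 1 by hydrogen in place of nitro on an aromatic carbon, with the nitro leaving a six-membered aromatic ring of carbon only. For the measured compounds named here, no measured step concerns this ring, so the direction of the step cannot be read from the other compounds; compound 1 itself stands only at a limit. The expectation for compound 4 is therefore cautious, and compound 4 is estimated at 8000 nM (range 2000 nM to 30000 nM), the expected step being an at least 1.2-fold lower number from compound 1 to compound 4 (0.09 log units; that floor lies within the scatter).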

Compound 4, half-maximal inhibitory concentration: > 10000 nM
Compound 4 gave a limit, no number (the forecaster's own chance of this, stated with the estimate: 50%); at least 1.2-fold (0.09 log units) between middle value and limit.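

In this assay compound 4, like compound 1, stands only at a limit, so no new step can be read between the two compounds: the limit of > 10000 nM in this assay, at which 3 of the 4 values shown sit. The compounds shown leave open whether hydrogen in place of nitro changes the antiproliferative activity at all.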